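Ethyl in Place of Methyl on the Pyrazole Nitrogen

This account rests on a few compounds, and the source may have more. Where it says the series, first, only, none or still open, it means among the compounds named here.

Compound 1 `c1ccc(-c2nc[nH]n2)c(NCC2=NCCN2)c1` was tested in an in vitro functional assay on cells (Fibroblast) for agonist activity at Alpha-1B adrenergic receptor (Homo sapiens) (on this read-out lower numbers stand for an effect already at smaller amounts and higher numbers for an effect only at larger amounts of compound), where compound 1 gives 5.01 nM. Compound 2 `Cc1n[nH]c(-c2ccccc2NCC2=NCCN2)n1` differs by 3-methyl-1H-1,2,4-triazol-5-yl in place of 1H-1,2,4-triazol-3-yl on an aromatic carbon. For compound 2 the assay reports only a limit, < 5020 nM. The step that the limit leaves unreadable from compound 1 to compound 2 thus cannot be sized. Compound 3 `Cn1nccc1-c1ccccc1NCC1=NCCN1` carries 1-methyl-1H-pyrazol-5-yl in place of 1H-1,2,4-triazol-3-yl on an aromatic carbon. For compound 3 the assay likewise returns a limit, < 100000 nM. The steps a step that the limit leaves unreadable from compound 1 to compound 3 and a step that the two limits leave unreadable from compound 2 to compound 3 stay unreadable as well; the values of compound 2 and compound 3 sit at the limit of < 5020 nM in this assay, at which 1 of the 3 values shown sits, and (the limit of < 100000 nM in this assay, at which 1 of the 3 values shown sits).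

Compound 4 `CCn1nccc1-c1ccccc1NCC1=NCCN1` carries methyl in place of hydrogen on a saturated chain carbon bound to an aromatic nitrogen, which, cut one bond further out, reads methyl to ethyl. None of the three measured steps can be read, so they give no size for this move, and compound 3 itself stands only at a limit. The step is expected to stay small, a step that the limit leaves unreadable from compound 3 to compound 4. For compound 4 the expected value is 5000 nM, estimated between 200 nM and 80000 nM.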

Compound 4, half-maximal effective concentration: < 100000 nM
Compound 4: a limit, no number; the forecaster's own chance of this, stated with the estimate: 50%; the middle value lies beyond the limit too.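

Among these compounds, compound 3 and compound 4 are both reported in this assay only as limits, so no step between them can be read. The compounds shown leave open whether going from methyl to ethyl changes the effect at all, and by how much.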